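The source may hold more compounds than are shown below. What is called first, only, known or untested is meant among the compounds shown, and "the series" means these compounds.

Of the compounds shown here, three in a shared core have been measured in a functional assay for antagonist activity at Neuropeptide Y receptor type 2 (Homo sapiens); on this read-out higher numbers stand for weaker inhibition and lower numbers for stronger inhibition. Compound 1 `CCN(CC)c1ccc(NC(=S)N2CCC(C(O)(c3ccccc3)c3ccccc3)CC2)cc1Cl` gives 85 nM in this assay. Compound 2 `CC(C)Oc1ccc(NC(=S)N2CCC(C(O)(c3ccccc3)c3ccccc3)CC2)cc1C#N` gives 899 nM in this assay. Compound 3 `CCOc1ccc(OC(=O)N2CCC(C(O)(c3ccccc3)c3ccccc3)CC2)cc1` gives 1580 nM in this assay, the highest of the three numbers; its number sits within the scatter of that of compound 2, while that of compound 1 lies well below it, beyond the scatter. Compound 4 `CS(=O)(=O)c1ccc(OC(=O)N2CCC(C(O)(c3ccccc3)c3ccccc3)CC2)cc1` differs from compound 3 in one place: methylsulfonyl in place of ethoxy on an aromatic carbon, para to a large group, so that the 4-ethoxyphenoxy of compound 3 becomes 4-(methylsulfonyl)phenoxy. No measured pair among these three compounds shows this change, so nothing among them fixes its size or direction. Since the change is made on the compound with the highest number, compound 4 is expected to stay near that number, with a modest drift toward weaker inhibition, an estimated step of a 1.6-fold higher number from compound 3 to compound 4 (0.20 log units; within the scatter). Compound 4 is therefore estimated to give 2500 nM in this assay, with a range from 800 nM to 8000 nM.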

Compound 4, half-maximal inhibitory concentration: 141 nM
Compound 4: the middle estimate sits 18-fold (1.25 log units) above what was measured; the whole stated range lies above it.
By their numbers in this assay, from the lowest: compounds 1 and 4 (each within the scatter of the next); then compounds 2 and 3 (each within the scatter of the next).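

In this assay, methylsulfonyl in place of ethoxy on an aromatic carbon, para to a large group, gives an 11-fold lower number from compound 3 to compound 4 (1.05 log units; beyond the scatter). This is the only single-place change shown, and so the first sign that the group at this position can shift the number substantially, here toward stronger inhibition. No measured evidence on the cause of this step is at hand.

On these data alone, it remains open whether this shift is particular to methylsulfonyl or would also appear with another group at this position, such as an amine, a carboxylic acid or a longer alkoxy chain. As far as these compounds go, it is also open whether the same change would have a similar effect in the core of compound 1, since the step rests on a single pair.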